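The source may report more compounds than this note shows. Statements on the series, on what has been measured and on what is new or still open speak of the compounds shown alone.

In a toxicity assay on NIH3T3 cells (Mus musculus) for cytotoxicity, read by resazurin assay (a higher number here means that more compound is needed for the effect, a lower number that less compound is needed), compound 3 `Fc1ccc(Cn2cncc2CNc2ccc(-c3nc4ccccc4s3)c(-c3ccccc3)c2)c(F)c1` gives > 1000 nM, which is a limit and not a number. Compound 1 `c1ccc(-c2ccc(Cn3cncc3CNc3ccc(-c4nc5ccccc5s4)c(-c4ccccc4)c3)cc2)cc1` gives > 1000 nM, also only a limit. Compound 2 `CC(C)c1ccc(Cn2cncc2CNc2ccc(-c3nc4ccccc4s3)c(-c3ccccc3)c2)cc1` gives > 1000 nM, again only a limit. Compound 4 `CCc1ccc(Cn2cncc2CNc2ccc(-c3nc4ccccc4s3)c(-c3ccccc3)c2)cc1` differs from compound 3 by 4-ethylphenyl in place of 2,4-difluorophenyl on a saturated chain carbon bound to an aromatic nitrogen, with 4-ethylphenyl in place of 2,4-difluorophenyl on a saturated chain carbon bound to an aromatic nitrogen. The changes at that place are a step that the two limits leave unreadable from compound 1 to compound 3 and a step that the two limits leave unreadable from compound 2 to compound 3, and a step that the two limits leave unreadable from compound 1 to compound 2 lies elsewhere. None of these has a readable size, so they give no direction, and no step beyond the scatter is expected in this assay. The expected result is a step that the limit leaves unreadable from compound 3 to compound 4. For compound 4 the estimate is 2000 nM, with an expected range of 800 nM to 6000 nM.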

Compound 4, half-maximal effective concentration: > 1000 nM
Compound 4: only a limit was reported; the forecaster's own chance of this, stated with the estimate: 85%; the middle value is on the limit's open side.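

In this assay compound 4 gives > 1000 nM as a limit only. Within the data shown here, no step among compounds 1, 2, 3 and 4 can be read: the limit of > 1000 nM in this assay, at which 4 of the 4 values shown sit. The compounds shown leave open what concentration any of the four needs for the effect, and whether the change of group alters it at all.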